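This account rests on a few compounds, and the source may have more. Where it says the series, first, only, none or still open, it means among the compounds named here.

Measured in a functional assay on PC-3 cells (Homo sapiens) for cytotoxicity, read by MTT assay; on this read-out higher numbers stand for weaker inhibition and lower numbers for stronger inhibition:
- compound 1 `COc1ccc2cc([C@H](C)c3nnc(SCc4ccc(Cl)cc4)n3-c3ccc(F)cc3)ccc2c1`: <= 400000 nM (a limit)
- compound 2 `COc1ccc(CSc2nnc([C@@H](C)c3ccc4cc(OC)ccc4c3)n2-c2ccc(Cl)cc2)cc1`: <= 400000 nM (a limit)
- compound 3 `COc1ccc2cc([C@H](C)c3n[nH]c(=S)n3-c3cccc(Cl)c3)ccc2c1`: "not determined" (no result reported)

In this assay compound 2 gives <= 400000 nM, which is a limit and not a number. Compound 1 shares that same limit, so the two cannot be ordered against each other. The overall picture is the limit of <= 400000 nM in this assay, at which 2 of the 3 values shown sit. Within the data shown here, compound 3 adds no result, and the series offers no measured step between compounds that differ in one place.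

The next compound is compound 4 `COc1ccc2cc([C@H](C)c3nnc(SCc4ccc(F)cc4)n3-c3ccc(Cl)cc3)ccc2c1`. It carries fluoro in place of methoxy on an aromatic carbon, para to a large group, so 4-methoxybenzyl becomes 4-fluorobenzyl: fluoro in place of methoxy on an aromatic carbon. Among the measured compounds shown here, no measured step calibrates this kind of change, so the expectation for this assay is loose. A modest move towards lower numbers is expected, though a result beyond the scatter is not assured, and compound 4 may also come back as a limit rather than a number. The expected change is a step that the limit leaves unreadable from compound 2 to compound 4. For compound 4 the estimated value is 150000 nM, with an expected range from 25000 nM to 400000 nM.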

Compound 4, half-maximal inhibitory concentration: 10800 nM
Compound 4: middle estimate off by 14-fold (1.14 log units), on the high side, and the stated range ends above it.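

In this assay no step can be read from compound 2 to compound 4, because compound 2 carries a limit and not a number: the limit of <= 400000 nM in this assay, at which 2 of the 4 values shown sit.

The compounds shown leave open how large a change fluoro in place of methoxy on an aromatic carbon brings, as 4-methoxybenzyl becomes 4-fluorobenzyl.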